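Swapping the group on the carbonyl of compound 3

The source may hold more compounds than are shown below. What is called first, only, known or untested is meant among the compounds shown, and "the series" means these compounds.

In an in vitro ADME assay on microsomes (Rattus norvegicus) for metabolic stability (a lower number here means that the compound disappears faster, a higher number that the compound lasts longer), compound 1 `CC(=O)N1CCc2c(C)c3c(n2-c2ccc(C(N)=O)c(c2)N[C@@H](C)[C@H](C)C1)CC(C)(C)CC3=O`, with methyl on a carbonyl carbon, gives 0.333 h. Compound 2 `Cc1c2c(n3c1CCN(C(=O)C(C)(C)N)C[C@@H](C)[C@H](C)Nc1cc-3ccc1C(N)=O)CC(C)(C)CC2=O` gives only a limit, > 0.5 h. Compound 3 `Cc1c2c(n3c1CCN(C(=O)C1(N)CC1)C[C@@H](C)[C@H](C)Nc1cc-3ccc1C(N)=O)CC(C)(C)CC2=O` also gives only a limit, > 0.5 h. Compound 3 therefore has no exact number and stands at the limit of > 0.5 h in this assay, at which 2 of the 3 values shown sit.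

Compound 4 `Cc1c2c(n3c1CCN(C(=O)[C@H](C)O)C[C@@H](C)[C@H](C)Nc1cc-3ccc1C(N)=O)CC(C)(C)CC2=O` has 1-hydroxyethyl in place of 1-aminocyclopropyl on a carbonyl carbon. For the measured compounds named here, no measured compound carries 1-hydroxyethyl, so the evidence is indirect. Two measured steps change the same place: an at least 1.5-fold higher number from compound 1 to compound 2 (0.17 log units; that floor lies within the scatter) and an at least 1.5-fold higher number from compound 1 to compound 3 (0.17 log units; that floor lies within the scatter). The third, a step that the two limits leave unreadable from compound 2 to compound 3, gives no size at all.

With no readable size to build on, no change beyond the scatter is expected, and the expected step is a step that the limit leaves unreadable from compound 3 to compound 4. The half-life estimated for compound 4 is 0.55 h, with an expected range of 0.25 h to 1.2 h.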

Compound 4, half-life: 0.483 h
Compound 4: the middle estimate sits 1.1-fold (0.06 log units) above what was measured, within the range that was stated.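

With 1-hydroxyethyl on the carbonyl, this position gives its first step of readable size in this assay: a 1.5-fold higher number from compound 1 to compound 4 (0.16 log units; within the scatter). Against the two groups that carry an amine, only floors can be stated, an at least 1.0-fold lower number from compound 3 to compound 4 (0.01 log units; that floor lies within the scatter) and an at least 1.0-fold lower number from compound 2 to compound 4 (0.01 log units; that floor lies within the scatter), so 1-hydroxyethyl is not shown to differ from either group. These two comparisons remain open-ended, since compound 2 and compound 3 have no exact number: the limit of > 0.5 h in this assay, at which 2 of the 4 values shown sit.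

On these data alone, how far compound 2 and compound 3 lie beyond that limit remains unknown, so it cannot be told whether 1-aminocyclopropyl or 1-amino-1-methylethyl truly lasts longer than 1-hydroxyethyl. The compounds shown also leave open how a carboxylic acid or a longer chain on this carbonyl would behave, and whether the mirror-image form of 1-hydroxyethyl would read the same.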